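This account rests on a few compounds, and the source may have more. Where it says the series, first, only, none or still open, it means among the compounds named here.

Measured in a functional assay on HeLa cells (Homo sapiens) for inhibition, read by MTT assay, with a stated time of 48 h; a lower number here means a stronger inhibitor, a higher number a weaker inhibitor:

- compound 1, `COc1ccc(C(c2c[nH]c3ccc(Br)cc23)c2c[nH]c3ccc(Br)cc23)cc1OC`: 6100 nM
- compound 2, `CN(C)c1ccc(C(c2c[nH]c3ccc(Br)cc23)c2c[nH]c3ccc(Br)cc23)cc1`: 12800 nM
- compound 3, `Brc1ccc(C(c2c[nH]c3ccc(Br)cc23)c2c[nH]c3ccc(Br)cc23)cc1`: 1500 nM

These three compounds share one core and differ only in the group on a saturated chain carbon bound to two aromatic carbons. Among the three numbers in this assay, compound 1 holds the second highest; the nearest is compound 2, reached by a 2.1-fold higher number from compound 1 to compound 2 (0.32 log units; beyond the scatter), and the furthest is compound 3, reached by a 4.1-fold lower number from compound 1 to compound 3 (0.61 log units; beyond the scatter). The remaining pair shows an 8.5-fold lower number from compound 2 to compound 3 (0.93 log units; beyond the scatter).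

Compound 4, `CCCCCCCC(c1c[nH]c2ccc(Br)cc12)c1c[nH]c2ccc(Br)cc12`, is not yet measured. It differs from compound 1 as follows: heptyl in place of 3,4-dimethoxyphenyl on a saturated chain carbon bound to two aromatic carbons

Both measured steps from compound 1 exchange the group at this same place for another six-membered aromatic ring, and they run in opposite directions, one modestly upward and one modestly downward. Among the measured compounds shown here, no measured step exchanges an aromatic ring for a chain, so the three compounds give no firm direction for compound 4. Compound 4 is therefore expected to land near compound 1, with a 1.1-fold higher number from compound 1 to compound 4 (0.06 log units; within the scatter) as the expected step and a wide range on either side. The estimate for compound 4 in this assay is 7000 nM, expected to fall between 1500 nM and 30000 nM.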

Compound 4, half-maximal inhibitory concentration: 1300 nM
For compound 4 the middle estimate is 5.4-fold (0.73 log units) above the measured one; measured number outside the range, below it.
By their numbers in this assay, from the lowest: compounds 4 and 3 (each within the scatter of the next); then compound 1; then compound 2.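

In this assay, an aromatic ring on this saturated chain carbon bound to two aromatic carbons turns out not to be required: putting heptyl there gives a 4.7-fold lower number from compound 1 to compound 4 (0.67 log units; beyond the scatter) and a 9.8-fold lower number from compound 2 to compound 4 (0.99 log units; beyond the scatter) and, against the bromo-bearing ring, only a 1.2-fold lower number from compound 3 to compound 4 (0.06 log units; within the scatter) and so no real difference. Among the compounds shown here, the earlier compounds exchanged only one six-membered aromatic ring for another, so they could show how the number moves among such rings, but not that a chain with no ring at all can match 4-bromophenyl here and lie clearly under both 3,4-dimethoxyphenyl and 4-(dimethylamino)phenyl. No accompanying measurement offers a reason for these steps.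

How the number depends on chain length stays open, as the compounds shown include neither a butyl nor a decyl chain, and neither a branched chain nor a chain ending in an amine or a carboxylic acid. They also leave open whether a saturated ring such as cyclohexyl would behave like heptyl, and whether heptyl keeps its standing on a core without the two bromo groups.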